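The compounds below may be only part of what the source reports. "The series", "measured", "known", "first", "only" and "open" are said of these compounds alone.

Working notes on the series. Three compounds share one core; compound 1 `COc1cc(NC(C)CCCNC(=O)NNC(=O)Nc2ccc(Br)cc2)c2ncccc2c1` is the longest, compound 2 `COc1cc(NC(C)CCCNC(=O)Nc2ccc(C(F)(F)F)cc2)c2ncccc2c1` and compound 3 `COc1cc(NC(C)CCCNC(=O)Nc2cccc(O)c2)c2ncccc2c1` carry a substituted phenyl directly on the amide-type nitrogen. In a functional assay on MOLT-4 cells (Homo sapiens) for inhibition, read by MTT assay, with a stated time of 72 h (on this read-out lower numbers stand for stronger inhibition and higher numbers for weaker inhibition), compound 1 gives 209000 nM, compound 2 gives 20000 nM and compound 3 gives 24000 nM. Compound 3 thus sits in the stronger pair of the three: the step of an 8.7-fold lower number from compound 1 to compound 3 (0.94 log units; beyond the scatter) is clear, while the step of a 1.2-fold higher number from compound 2 to compound 3 (0.08 log units; within the scatter) is within the scatter, so compounds 2 and 3 cannot be told apart on these numbers.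

Compound 4 `COc1cc(NC(C)CCCNC(=O)Nc2cccc(C(F)(F)F)c2)c2ncccc2c1` is not yet measured. It differs from compound 3 by trifluoromethyl in place of hydroxy on an aromatic carbon. The step that bears on this change most directly is a 1.2-fold higher number from compound 2 to compound 3 (0.08 log units; within the scatter), which swaps a hydroxy-bearing phenyl for a trifluoromethyl-bearing phenyl, though at a different ring carbon; it showed nothing beyond the scatter. The large step of a 10-fold lower number from compound 1 to compound 2 (1.02 log units; beyond the scatter) concerns the loss of the carbamoylamino linker, not the phenyl substituent, and does not speak to this change. On that basis no change beyond the scatter is expected in this assay from compound 3 to compound 4, the estimated step being a 1.2-fold lower number from compound 3 to compound 4 (0.08 log units; within the scatter). Compound 4 is estimated at 20000 nM, with a range from 8000 nM to 50000 nM.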

Compound 4, half-maximal inhibitory concentration: 20000 nM
The estimate for compound 4 equals the measured number at the digits printed, and the stated range covers the measured number.
By their numbers in this assay, from the lowest: compounds 2, 4 and 3 (each within the scatter of the next); then compound 1.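

In this assay the step of a 1.2-fold lower number from compound 3 to compound 4 (0.08 log units; within the scatter) gives the first direct read on trifluoromethyl in place of hydroxy at the same ring carbon, meta to a large group, and the two compounds cannot be told apart. Among these compounds, the step of no change at the digits printed from compound 2 to compound 4 (within the scatter) is the first comparison of 3-(trifluoromethyl)phenyl with 4-(trifluoromethyl)phenyl, and it shows no separation, while the step of a 10-fold lower number from compound 1 to compound 4 (1.02 log units; beyond the scatter) places compound 4 clearly apart from compound 1, as with compounds 2 and 3. No measured evidence is available to explain these results.

The compounds shown leave open whether an amine or a carboxylic acid at this ring carbon would also stay within the scatter of compound 3. They also leave open how a longer chain between the shared core and the amide-type nitrogen would affect the number.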